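Replacing dimethylamino with (tert-butyl)amino at the chain end

The source may hold more compounds than are shown below. What is called first, only, known or untested is meant among the compounds shown, and "the series" means these compounds.

Among the measured compounds shown here, the three compounds measured so far share one core and differ in the group at the end of a side chain. In a functional assay (aorta) with Rattus norvegicus as the target (on this read-out lower numbers stand for stronger inhibition and higher numbers for weaker inhibition), compound 3 (`CC(C)c1cn2ccccc2c1S(=O)(=O)c1ccc(OCCCN(C)C)cc1`) gives 390 nM and lies within the scatter of compound 1 (`CC(C)c1cn2ccccc2c1S(=O)(=O)c1ccc(OCCCN2CCN(c3ccccc3)CC2)cc1`), which gives 205 nM on the same scale, while compound 2 (`CCCCCN(CCCCC)CCCOc1ccc(S(=O)(=O)c2c(C(C)C)cn3ccccc23)cc1`) gives 89.6 nM as a clearly lower number.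

Compound 4 (`CC(C)c1cn2ccccc2c1S(=O)(=O)c1ccc(OCCCNC(C)(C)C)cc1`) differs from compound 3 in one group ((tert-butyl)amino in place of dimethylamino on a saturated chain carbon, three bonds along the chain from an oxygen on an aromatic ring), with (tert-butyl)amino in place of dimethylamino on a saturated chain carbon.

For the measured compounds named here, no measured step makes this exact swap, but three change the same place. Replacing dipentylamino with dimethylamino gave a 4.4-fold higher number from compound 2 to compound 3 (0.64 log units; beyond the scatter) as the largest shift, and replacing 4-phenylpiperazin-1-yl with dimethylamino gave a 1.9-fold higher number from compound 1 to compound 3 (0.28 log units; within the scatter) as a shift inside the scatter. Exchanging those two other groups gave a 2.3-fold lower number from compound 1 to compound 2 (0.36 log units; beyond the scatter) as a modest shift. Even the largest of these is modest, and the hydrogen-bond donor that enters has no counterpart among the measured compounds.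

In this assay no step beyond the scatter is therefore expected, with any drift more likely towards a lower number. The estimated step is a 1.3-fold lower number from compound 3 to compound 4 (0.13 log units; within the scatter) in size. Compound 4 is estimated at 290 nM (expected range 110 nM to 700 nM).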

Compound 4, half-maximal inhibitory concentration: 41.8 nM
Compound 4: middle estimate off by 6.9-fold (0.84 log units), on the high side; measured number below the stated range.
By their numbers in this assay, from the lowest: compound 4; then compound 2; then compounds 1 and 3 (each within the scatter of the next).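

In this assay, (tert-butyl)amino in place of dimethylamino gives a 9.3-fold lower number from compound 3 to compound 4 (0.97 log units; beyond the scatter) and so moves the number further than any step among the first three compounds. Compound 4 also sits clearly below both compounds with larger chain-end groups (a 2.1-fold lower number from compound 2 to compound 4 (0.33 log units; beyond the scatter) and a 4.9-fold lower number from compound 1 to compound 4 (0.69 log units; beyond the scatter)), so at this position the lowest number of the four comes from neither of those larger groups. The swap brings in a hydrogen-bond donor and extra carbons together, and nothing shown here gives a reason for the shift or separates these two changes.

As far as these compounds go, what stays open is which part of the change matters: methylamino would keep the hydrogen on the nitrogen without the tert-butyl carbons, while (tert-butyl)(methyl)amino would keep those carbons without that hydrogen. From the compounds shown here alone, it is also open whether (tert-butyl)amino behaves the same way on a shorter or longer chain, or with another group in place of the isopropyl on the shared core.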